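Following compound 1 from amide to acid

The compounds below may be only part of what the source reports. "The series", "measured", "known", "first", "only" and "open" are said of these compounds alone.

Values in a functional assay on MCF7 cells (Homo sapiens) for cytotoxicity, read by MTT assay, with a stated time of 72 h (on this read-out lower numbers stand for stronger inhibition and higher numbers for weaker inhibition), so far:
- compound 1 `Cc1oc2ncnc(Nc3cccc(Cl)c3)c2c1C(=O)NC(C)C` gives 191000 nM here
- compound 2 `CCOC(=O)c1c(C)oc2ncnc(Nc3ccc(OCc4ccccc4)cc3)c12` gives only a limit, > 1000000 nM here
- compound 3 `Cc1oc2ncnc(Nc3cccc(Br)c3)c2c1CO` gives 11000 nM here

Of the two values that are true numbers in this assay compound 1 holds the higher one, and compound 3 lies lower, beyond the scatter. The entry for compound 2 is a limit and not a number, so it cannot be placed beside them.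

The step followed here leads from compound 1 to compound 4 `Cc1oc2ncnc(Nc3cccc(Cl)c3)c2c1C(=O)O` which has not yet been measured. The change is hydroxy in place of isopropylamino on a carbonyl carbon and the same difference, cut one bond further out, reads isopropylcarbamoyl to carboxy. Among the measured compounds shown here, no measured pair in this set shows that change, so the expectation has no direct precedent. Compound 1 at 191000 nM and compound 3 at 11000 nM show how far the numbers spread, so any range must stay wide. In this assay no step beyond the scatter is expected, and the estimate reads a 1.0-fold higher number from compound 1 to compound 4 (0.02 log units; within the scatter) as the expected step. For compound 4 the estimated value is 200000 nM with an expected range of 20000 nM to 900000 nM around it.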

Compound 4, half-maximal inhibitory concentration: 57500 nM
Beside the measured number, compound 4's estimate is 3.5-fold (0.54 log units) above it; the range from low to high includes it.
By their numbers in this assay, from the lowest: compound 3; then compound 4; then compound 1. At a limit, above all of these: compound 2.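

In this assay, among the compounds shown here, this is the first reading of a single change at one place on the shared core: a 3.3-fold lower number from compound 1 to compound 4 (0.52 log units; beyond the scatter). Hydroxy in place of isopropylamino on the carbonyl carbon swaps a group of 4 heavy atoms for one of 1 heavy atom while each group keeps 1 hydrogen-bond donor, and the number does not rise, so the isopropylcarbamoyl group is not needed to keep compound 4 at or below the level of compound 1 in this assay. Nothing measured here gives a reason for this modest step.

One step cannot separate the loss of the isopropyl chain from the change of amide to carboxylic acid: a small amine such as methylamino on the same carbonyl carbon, or a longer chain such as n-butylamino, would pull the two apart, and a methoxy group would show what the hydroxy hydrogen contributes. Also open, from the compounds shown here alone, is whether the same change gives a step of this size and direction when the core carries different groups elsewhere.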